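Amide in place of urea on the shared core

The compounds below may be only part of what the source reports. "The series", "measured", "known", "first", "only" and "open" are said of these compounds alone.

Compound 1 `O=C(Nc1ccccc1Cl)Nc1nn(-c2ccccc2)c(=O)c2ccccc12` gives 49% in an assay on CHO cells for displacement of a labelled ligand from adenosine receptor A3 (Homo sapiens), tested at 1 uM (on this read-out higher numbers stand for more inhibition at the one concentration tested (going by the name of the read-out) and lower numbers for less inhibition), and compound 2 `O=C(Nc1ccc(Cl)cc1)Nc1nn(-c2ccccc2)c(=O)c2ccccc12` gives 13% in this assay, with a number 36 percentage points lower from compound 1 to compound 2 (beyond the scatter). Compound 2 therefore stands lowest of the two numbers measured, its nearest neighbour being compound 1 at a number beyond the scatter above it. Compound 3 `COc1ccc(C(=O)Nc2nn(-c3ccccc3)c(=O)c3ccccc23)cc1` differs from compound 2 in one place: 4-methoxyphenyl in place of (4-chlorophenyl)amino on a carbonyl carbon. Among the measured compounds shown here, the one measured step, the exchange of a 4-chlorophenyl for a 2-chlorophenyl on an amide-type nitrogen, does not bear directly on this change, since here the (4-chlorophenyl)amino group itself is removed and a 4-methoxyphenyl is joined to the carbonyl carbon; no measured pair shows such a change. Compound 3 is expected to give an estimated 25% in this assay, within 5% to 55%, which would mean an expected a number 12 percentage points higher from compound 2 to compound 3 (beyond the scatter).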

Compound 3, a percentage reported as inhibition, at one concentration (the size of the read-out at that concentration, not a potency): 10%
For compound 3 the middle estimate is 15 percentage points above the measured one; low and high end bracket the measured number.
By their numbers in this assay, from the lowest: compounds 3 and 2 (each within the scatter of the next); then compound 1.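

In this assay, 4-methoxyphenyl in place of (4-chlorophenyl)amino on a carbonyl carbon gives a number 3 percentage points lower from compound 2 to compound 3 (within the scatter), so this change leaves the read-out within the scatter for this pair. Measured against the (2-chlorophenyl)amino group at the same place, 4-methoxyphenyl gives a number 39 percentage points lower from compound 1 to compound 3 (beyond the scatter), which shows that the outcome of removing the amino-linked group depends on which chlorophenyl group leaves, and among these three compounds only compound 1 stands clear of the others. Nothing available explains these numbers.

From the compounds shown here alone, it remains open how a 2-chlorophenyl joined directly to the carbonyl carbon, or a (4-methoxyphenyl)amino group at that place, would read in this assay. Also open, going by these compounds, is whether a morpholine or a short alkyl chain on the carbonyl carbon would give a number nearer that of compound 1.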